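The source may report more compounds than this note shows. Statements on the series, on what has been measured and on what is new or still open speak of the compounds shown alone.

Two compounds share one core and differ only in the group on the amide-bearing aromatic ring. Compound 1 `C#Cc1cccc(NC(=O)CCc2cccc3c2B(O)OC3)c1` carries an ethynyl group, and in a functional assay on SK-OV-3 cells (Homo sapiens) for antiproliferative activity, read by MTT assay, with a stated time of 72 h (on this read-out higher numbers stand for weaker inhibition and lower numbers for stronger inhibition), compound 1 gives 980 nM, the lower of the two numbers, though within the scatter of compound 2 `O=C(CCc1cccc2c1B(O)OC2)Nc1ccc2ccccc2c1`, which gives 1400 nM. Compound 3 `N#Cc1cccc(-c2cccc(NC(=O)CCc3cccc4c3B(O)OC4)c2)c1` differs from compound 1 in one place: 3-cyanophenyl in place of ethynyl on an aromatic carbon. Within the data shown here, no measured pair shows such a change, so no step beyond the scatter is expected in either direction. Compound 3 is expected to give 1200 nM, between 400 nM and 4000 nM. That estimate means a 1.2-fold higher number from compound 1 to compound 3 (0.09 log units; within the scatter).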

Compound 3, half-maximal inhibitory concentration: 120 nM
Beside the measured number, compound 3's estimate is 10-fold (1.00 log units) above it, and the stated range ends above it.
By their numbers in this assay, from the lowest: compound 3; then compounds 1 and 2 (each within the scatter of the next).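

In this assay, this aromatic carbon accepts a far larger group than ethynyl: 3-cyanophenyl, which adds a six-membered aromatic ring bearing a nitrile, gives an 8.2-fold lower number from compound 1 to compound 3 (0.91 log units; beyond the scatter). Among these compounds, the earlier compounds showed no step beyond the scatter, so this is the first sign that the group at this position can change the number. Nothing available explains this step.

On these data alone, it remains open whether the nitrile or the added ring accounts for the step, which a plain phenyl group would help to separate. As far as these compounds go, whether an amine or a carboxylic acid on the added ring would serve as well also remains open.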